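The compounds below may be only part of what the source reports. "The series", "measured", "known", "first", "only" and "open" are said of these compounds alone.

Measured so far:
Compound 1, `c1ccc2c(-c3cn4ccnc4c(-c4ccc5ncn(C6CCCCC6)c5c4)n3)cccc2c1`, gives 13.3%.
Compound 2, `Fc1ccc(-c2cn3ccnc3c(-c3ccc4ncn(C5CCCCC5)c4c3)n2)cc1`, gives 10.5%.

In a functional assay on EKVX cells (Homo sapiens) for inhibition, read by sulforhodamine B assay, with a stated time of 48 h, tested at 10 uM (on this read-out lower numbers stand for less inhibition and higher numbers for more inhibition at the one concentration tested (going by the name of the read-out)), compound 1 and compound 2 both stand low, and the two numbers lie within the scatter of each other. The one step measured, a number 2.8 percentage points lower from compound 1 to compound 2 (within the scatter), was within the scatter, so no shift beyond noise has been seen among these compounds.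

Compound 3, `Clc1ccc(-c2cn3ccnc3c(-c3ccc4ncn(C5CCCCC5)c4c3)n2)cc1`, differs from compound 2 by chloro in place of fluoro on an aromatic carbon. Going by the values given here, no measured step swaps these two groups, so the change itself gives no guide; what can be said is that the only step on record, from compound 1 to compound 2, produced nothing beyond the scatter, and compound 2 itself sits near the bottom of the read-out.

Compound 3 is therefore expected to show a step of about a number 1.5 percentage points higher from compound 2 to compound 3 (within the scatter), that is, no shift beyond the scatter. The estimate for compound 3 is 12%, with a range from 2% to 25%.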

Compound 3, a percentage reported as inhibition, at one concentration (the size of the read-out at that concentration, not a potency): 13.1%
For compound 3 the middle estimate is 1.1 percentage points below the measured one; low and high end bracket the measured number.
By their numbers in this assay, from the lowest: compounds 2, 3 and 1 (each within the scatter of the next).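

In this assay, going by these compounds alone, chloro in place of fluoro on an aromatic carbon para to a large group reads a number 2.6 percentage points higher from compound 2 to compound 3 (within the scatter), which is the first measured exchange of one halogen for the other at this position. Setting 4-chlorophenyl in place of naphthalen-1-yl reads a number 0.2 percentage points lower from compound 1 to compound 3 (within the scatter), so the naphthalen-1-yl, 4-fluorophenyl and 4-chlorophenyl compounds all lie within the scatter of one another. No measurement shown accounts for these readings.

As far as these compounds go, whether a group of another kind at this position, such as an amine, a carboxylic acid or a longer alkyl chain, would give a step beyond the scatter remains open. From the compounds shown here alone, all three compounds carry the same core, and what a different core would do also stays open.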